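A few compounds are considered here, and "the series" means these few. Any claim that something is new, unique, unknown or untested is made for them only; others in the source may bear on it.

Measured in a functional assay on HT-29 cells (Homo sapiens) for cytotoxicity, read by MTT assay, with a stated time of 72 h; a higher number here means a weaker inhibitor, a lower number a stronger inhibitor:
compound 1 `CN(C)CCNc1nc(-c2ccc(NC(=O)Nc3ccc(Cl)cc3)cc2)nc2ccsc12` gives 95 nM
compound 2 `CN(C)CCNc1nc(-c2ccc(NC(=O)Nc3ccc(Cl)cc3Cl)cc2)nc2ccsc12` gives 1320 nM
compound 3 `Cc1ccc(NC(=O)Nc2ccc(-c3nc(NCCN(C)C)c4sccc4n3)cc2)cc1` gives 2150 nM

Compound 1 stands lowest of the three numbers in this assay. The measured steps all lie on the urea side of the shared core: a 14-fold higher number from compound 1 to compound 2 (1.14 log units; beyond the scatter) and a 23-fold higher number from compound 1 to compound 3 (1.35 log units; beyond the scatter) are both large and beyond the scatter, while a 1.6-fold higher number from compound 2 to compound 3 (0.21 log units; within the scatter) stays within it.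

Compound 4 `CCN(CC)CCNc1nc(-c2ccc(NC(=O)Nc3ccc(Cl)cc3)cc2)nc2ccsc12` differs from compound 1 only on the chain side: diethylamino in place of dimethylamino on a saturated chain carbon, two bonds along the chain from a nitrogen on an aromatic ring. Within the data shown here, no measured step touches this chain, so the three measured steps give no direct read on the change. The urea side, where the large steps were seen, is unchanged between compound 1 and compound 4. With nothing measured on the chain, the working expectation is a step no larger than the scatter, a 1.3-fold higher number from compound 1 to compound 4 (0.10 log units; within the scatter), in this assay. Compound 4 is therefore estimated at 120 nM in this assay, with a range from 40 nM to 400 nM.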

Compound 4, half-maximal inhibitory concentration: 150 nM
Compound 4: middle estimate off by 1.3-fold (0.10 log units), on the low side, within the range that was stated.
By their numbers in this assay, from the lowest: compounds 1 and 4 (each within the scatter of the next); then compounds 2 and 3 (each within the scatter of the next).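

In this assay, the chain position takes diethylamino in place of dimethylamino with no change beyond the scatter: a 1.6-fold higher number from compound 1 to compound 4 (0.20 log units; within the scatter). Among these compounds, this is the only measured step on the chain side, and it stands apart in size from the large step on the urea side, a 14-fold higher number from compound 1 to compound 2 (1.14 log units; beyond the scatter), so the added carbons of diethylamino leave compound 4 in the same range as compound 1. No supporting data bear on the reason for this result.

On these data alone, whether the chain position stays this permissive with a pyrrolidine, a morpholine, a primary amine or a longer chain in place of dimethylamino remains open. Also open, as far as these compounds go, is whether diethylamino reads the same alongside the 2,4-dichlorophenyl or 4-methylphenyl urea partners.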